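Bromo in place of methyl on the shared core

A few compounds are considered here, and "the series" means these few. Any claim that something is new, unique, unknown or untested is made for them only; others in the source may bear on it.

In a functional assay on T47D cells (Homo sapiens) for cytotoxicity, read by MTT assay, with a stated time of 96 h (a lower number here means a stronger inhibitor, a higher number a weaker inhibitor), compound 1 `CCc1ccc(-c2ccc(-c3ccc(C(=N)N)cc3)o2)cc1` gives 3000 nM and compound 2 `Cc1ccc(-c2ccc(-c3ccc(C(=N)N)cc3)o2)cc1` gives 3100 nM. Among the measured compounds shown here, these two values lie within the scatter of each other, so compound 2 stands level with the only other compound measured so far. The next compound is compound 3 `N=C(N)c1ccc(-c2ccc(-c3ccc(Br)cc3)o2)cc1`, and the change leading to it is bromo in place of methyl on an aromatic carbon, turning 4-methylphenyl into 4-bromophenyl. For the measured compounds named here, only one measured step bears on this change, a 1.0-fold higher number from compound 1 to compound 2 (0.01 log units; within the scatter), which puts hydrogen in place of methyl on a saturated chain carbon bound to an aromatic carbon. Going by the values given here, that step alters the same substituent but lies within the scatter, and it offers only weak guidance, since no measured compound carries bromo. The estimated step is a 1.0-fold lower number from compound 2 to compound 3 (0.01 log units; within the scatter), so no shift beyond the scatter is expected in this assay. For compound 3 the expected value is 3000 nM, with an estimated range of 1200 nM to 7500 nM.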

Compound 3, half-maximal inhibitory concentration: 2400 nM
Beside the measured number, compound 3's estimate is 1.3-fold (0.10 log units) above it; the range from low to high includes it.
By their numbers in this assay, from the lowest: compounds 3, 1 and 2 (each within the scatter of the next).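

In this assay, compound 3 is the first compound shown to carry something other than a saturated carbon chain on this aromatic carbon, so the comparison now goes beyond the ethyl and methyl pair. Putting bromo in place of methyl gives a 1.3-fold lower number from compound 2 to compound 3 (0.11 log units; within the scatter), and putting bromo in place of ethyl gives a 1.3-fold lower number from compound 1 to compound 3 (0.10 log units; within the scatter); both steps lie within the scatter, so all three groups read level at this position and none of the three compounds goes against that. No supporting information is available to explain this level reading.

The compounds shown leave open whether the level reading would hold for quite different groups on this aromatic carbon, such as an amine, a carboxylic acid or a longer chain, since ethyl, methyl and bromo are the only groups seen here. On these data alone, it also remains open whether bromo would read the same way if the shared core were changed in any other place.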